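The compounds below may be only part of what the source reports. "The series", "measured", "known", "first", "only" and "open" are said of these compounds alone.

Working notes on the series. Compound 3 `CC(C)N1CCc2nc(C#Cc3ccccc3)ccc2C1=O` stands highest of the three numbers in a functional assay on HEK293 cells for negative allosteric modulation of metabotropic glutamate receptor 5 (Homo sapiens), read by FLIPR and calcium flux (a higher number here means a weaker inhibitor, a lower number a stronger inhibitor), where compound 3 gives 706 nM; compound 2 `COc1cccc(C#Cc2ccc3c(n2)CCN(C)C3=O)c1` gives 293 nM and compound 1 `CN1CCc2nc(C#Cc3cccc(Cl)c3)ccc2C1=O` gives 22 nM. Compound 4 `Cc1cccc(C#Cc2ccc3c(n2)CCN(C(C)C)C3=O)c1` differs from compound 3 by methyl in place of hydrogen on an aromatic carbon, placed meta to a large group. Among the measured compounds shown here, no measured step exchanges hydrogen for methyl on that ring. For the measured compounds named here, the only single-point step, a 13-fold higher number from compound 1 to compound 2 (1.12 log units; beyond the scatter), shows that the group at this position matters a great deal in this assay, and compound 1 and compound 3 together show that a substituted ring sits at the low end while the bare ring sits at the high end. A downward step, a 2.8-fold lower number from compound 3 to compound 4 (0.45 log units; beyond the scatter), is therefore expected. Compound 4 is estimated at 250 nM in this assay, within 80 nM to 800 nM.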

Compound 4, half-maximal inhibitory concentration: 4.8 nM
Compound 4: the middle estimate sits 52-fold (1.72 log units) above what was measured; the whole stated range lies above it.
By their numbers in this assay, from the lowest: compound 4; then compound 1; then compound 2; then compound 3.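

In this assay, the change from phenyl to 3-methylphenyl gives a 150-fold lower number from compound 3 to compound 4 (2.17 log units; beyond the scatter). A single added carbon on the bare ring therefore produces a step that exceeds even a 13-fold higher number from compound 1 to compound 2 (1.12 log units; beyond the scatter), so this position responds strongly to a small group as well as to an exchange of one substituent for another. Nothing measured here bears on why this step is so large. Open, as far as these compounds go, is whether ethyl or trifluoromethyl in the same place keeps the number this low, and whether methyl gives a comparable step with methyl instead of isopropyl on the amide nitrogen.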